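Thiophen-3-yl to thiophen-2-yl: a step at the limit

A few compounds are considered here, and "the series" means these few. Any claim that something is new, unique, unknown or untested is made for them only; others in the source may bear on it.

Values in a physicochemical assay for solubility, read by HPLC, with a stated time of 24 h (a lower number here means a less soluble compound, a higher number a more soluble compound), follow, each a limit and not a number:
Compound 1 `CC(C)(C)c1[nH]cnc1/C=c1\[nH]c(=O)/c(=C/c2cccc(C(=O)N3CCCCC3)c2)[nH]c1=O` gives < 0.1 ug/mL
Compound 2 `CC(C)(C)c1[nH]cnc1/C=c1\[nH]c(=O)/c(=C/c2cccc(C(=O)c3ccncc3)c2)[nH]c1=O` gives < 0.1 ug/mL
Compound 3 `CC(C)(C)c1[nH]cnc1/C=c1\[nH]c(=O)/c(=C/c2cccc(C(=O)c3ccsc3)c2)[nH]c1=O` gives < 0.1 ug/mL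

Compound 3 stands at < 0.1 ug/mL and that is a limit only. All the measured compounds share it (the limit of < 0.1 ug/mL in this assay, at which 3 of the 3 values shown sit). Compound 4 `CC(C)(C)c1[nH]cnc1/C=c1\[nH]c(=O)/c(=C/c2cccc(C(=O)c3cccs3)c2)[nH]c1=O` has thiophen-2-yl in place of thiophen-3-yl on a carbonyl carbon, the same atoms joined differently. Three measured changes at that carbonyl carbon bear on this, namely a step that the two limits leave unreadable from compound 1 to compound 2 and a step that the two limits leave unreadable from compound 1 to compound 3 and also a step that the two limits leave unreadable from compound 2 to compound 3 with no size to read in any of them. So no step beyond the scatter is expected in this assay and no direction can be given. The expected move (a step that the limit leaves unreadable from compound 3 to compound 4) is an estimate only. Compound 4 is estimated at 0.07 ug/mL with a range of 0.02 ug/mL to 0.3 ug/mL and a reading that is again only a limit is likely.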

Compound 4, solubility: < 0.1 ug/mL
Compound 4: a limit, no number (the forecaster's own chance of this, stated with the estimate: 85%); the middle value is on the limit's open side.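

Compound 4 gives only a limit, as do compound 1, compound 2 and compound 3, so no step among them can be read: the limit of < 0.1 ug/mL in this assay, at which 4 of the 4 values shown sit.

Going by these compounds, whether the group on the carbonyl carbon shifts solubility at all, and in which direction, remains open.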